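This account rests on a few compounds, and the source may have more. Where it says the series, first, only, none or still open, it means among the compounds named here.

Measured in the series so far:

compound 1, `COc1ccccc1NCC(=O)Oc1ccc2c(C)cc(=O)oc2c1` — 26.6%
compound 2, `Cc1cc(=O)oc2cc(OC(=O)CNc3nc4ccccc4s3)ccc12` — 40.4%
compound 3, `Cc1cc(=O)oc2cc(OC(=O)CNc3cccc([N+](=O)[O-])c3)ccc12` — 34%

All three numbers come from a functional assay on the whole organism (strain Wistar albino) for inhibition, with Rattus norvegicus as the target, read by paw edema, with stated times of 30 min and 3 h, at a dose of 20 mg/kg by the oral route; on this read-out higher numbers stand for more inhibition at the one dose given (going by the name of the read-out) and lower numbers for less inhibition. Compound 1 gives 26.6% and stands lowest of the three. Its nearest neighbour is compound 3 at 34%, a gap that lies within the scatter of repeated measurements, so no order between compound 1 and compound 3 can be read from these two numbers. Compound 2 at 40.4% sits beyond the scatter above compound 1.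

Compound 4, `Cc1cc(=O)oc2cc(OC(=O)CNN3C=NNC3)ccc12`, is the one not yet measured. Relative to compound 1 the change is a group of 5 heavy atoms (2 carbon, 3 nitrogen; one five-membered non-aromatic ring with 3 hetero atoms) in place of a group of 8 heavy atoms (7 carbon, 1 oxygen; one six-membered aromatic ring of carbon only), on an amine nitrogen. Among the compounds with values here, no step between two measured compounds that differ in this one place exists, so the size of the effect of such a change is unknown here; the three measured numbers span a narrow band, and on that basis only a small step is expected, with its direction open and most likely none beyond the scatter.

Compound 4 is therefore expected to give about 30% in this assay, in a range from 20% to 42%. This estimate means a step of a number 3.4 percentage points higher from compound 1 to compound 4 (within the scatter) that stays within the scatter.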

Compound 4, a percentage reported as inhibition, in the whole organism at one dose (the size of the read-out at that dose, not a potency): 27.6%
Compound 4: the middle estimate sits 2.4 percentage points above what was measured, and the stated range covers the measured number.
By their numbers in this assay, from the lowest: compounds 1, 4, 3 and 2 (each within the scatter of the next, the first and the last beyond it).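

In this assay the first step readable at this amine nitrogen is a number 1 percentage points higher from compound 1 to compound 4 (within the scatter), so exchanging 2-methoxyphenyl for the five-membered non-aromatic ring with 3 hetero atoms gives no difference that can be read. At this one dose, then, a six-membered aromatic ring of carbon only is not needed on this amine nitrogen for a read-out at this level, and the smaller group with more hydrogen-bond acceptors and a hydrogen-bond donor serves equally within the scatter. Nothing available bears on why the two groups read alike.

Still open, as far as these compounds go, is whether another group on this amine nitrogen, such as a carboxylic acid, a primary amine or a longer chain, would give a step beyond the scatter. A single-dose reading also leaves open whether compound 1 and compound 4 would stay alike at other doses.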